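Adding a second fluorine to the benzoyl group of compound 3

This account rests on a few compounds, and the source may have more. Where it says the series, first, only, none or still open, it means among the compounds named here.

Measured so far:
- compound 1 `Fc1ccc(CN2CCC(NCCSC(c3ccc(F)cc3)c3ccc(F)cc3)CC2)cc1`: 100%
- compound 2 `OC(Cc1ccccc1)CN1CCC(NCCSC(c2ccc(F)cc2)c2ccc(F)cc2)CC1`: 100%
- compound 3 `O=C(c1ccc(F)cc1)N1CCC(NCCSC(c2ccc(F)cc2)c2ccc(F)cc2)CC1`: 100%

In an ADME assay on microsomes from liver (Rattus norvegicus) for metabolic stability, read by LC-MS, using NADPH, tested at 10 uM (on this read-out higher numbers stand for a more stable compound and lower numbers for a less stable compound), compound 3 gives 100%. Compound 3 stands level with compounds 1 and 2, whose values lie within the scatter of its own: the step from compound 1 to compound 3 was no change at the digits printed from compound 1 to compound 3 (within the scatter), and the step from compound 2 to compound 3 was no change at the digits printed from compound 2 to compound 3 (within the scatter); likewise, no change at the digits printed from compound 1 to compound 2 (within the scatter). All three share the same core, and the changes made so far on the amine nitrogen in the ring have left the read-out unchanged.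

Compound 4 `O=C(c1ccc(F)cc1F)N1CCC(NCCSC(c2ccc(F)cc2)c2ccc(F)cc2)CC1` differs from compound 3 by fluoro in place of hydrogen on an aromatic carbon, so that the (4-fluorophenyl)carbonyl becomes a (2,4-difluorophenyl)carbonyl. Going by the values given here, none of the measured steps touches this part of the structure; the closest is the step from compound 1 to compound 3, which exchanged the whole group on that nitrogen and was still within the scatter. Since every change so far has been within the scatter and compound 3 already sits at the top of the scale, the step of a number 2 percentage points lower from compound 3 to compound 4 (within the scatter) in this assay is expected to be none beyond the scatter. Compound 4 is therefore estimated at 98%, with a range from 85% to 100%.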

Compound 4, percent of the compound remaining: 100%
Beside the measured number, compound 4's estimate is 2 percentage points below it; the measured number falls inside the stated range.
By their numbers in this assay, from the lowest: compounds 1, 2, 3 and 4 (each within the scatter of the next).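

In this assay, fluoro in place of hydrogen on an aromatic carbon, ortho to a large group and meta to a fluoro group, gave no change at the digits printed from compound 3 to compound 4 (within the scatter). This is the first step shown that alters the aromatic ring of the (4-fluorophenyl)carbonyl itself rather than exchanging the whole group on the amine nitrogen in the ring, and so it extends the flat reading to this position, at least for this single small substituent. The (2,4-difluorophenyl)carbonyl also reads the same against the two other groups on that nitrogen, with no change at the digits printed from compound 2 to compound 4 (within the scatter) and no change at the digits printed from compound 1 to compound 4 (within the scatter), and nothing at hand bears on why this read-out stays level across the series.

From the compounds shown here alone, with all four compounds level, the read-out does not yet separate any group at this position, so it remains open whether a larger or different substituent there, such as a methoxy group, an amine or a carboxylic acid, would move the number in this assay. Going by these compounds, it is equally open how the read-out would respond to a change away from the amine nitrogen in the ring, for instance a longer chain in place of the one carrying the sulfur atom of the shared core.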